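A few compounds are considered here, and "the series" means these few. Any claim that something is new, unique, unknown or untested is made for them only; others in the source may bear on it.

Compound 1 has the structure `NC(=O)CC[C@H](N)C(=O)NS(=O)(=O)OC[C@H]1O[C@@H](n2cnc3c(N)ncnc32)[C@H](O)[C@@H]1O` and compound 2 the structure `CC[C@H](C)[C@H](N)C(=O)NS(=O)(=O)OC[C@H]1O[C@@H](n2cnc3c(N)ncnc32)[C@H](O)[C@@H]1O`. In a functional assay on PBMC cells (Homo sapiens) for inhibition (on this read-out lower numbers stand for stronger inhibition and higher numbers for weaker inhibition), compound 1 gives 800 nM, while in this assay compound 2 gives 5600 nM, the highest of the two numbers measured. Among the compounds with values here, the one measured step is a 7.0-fold higher number from compound 1 to compound 2 (0.85 log units; beyond the scatter). Compound 3, `Nc1ncnc2c1ncn2[C@@H]1O[C@H](COS(=O)(=O)NC(=O)[C@@H]2CCN2)[C@@H](O)[C@H]1O`, has not yet been measured in this assay. It differs from compound 2 as follows: azetidin-2-yl in place of 1-amino-2-methylbutyl on a carbonyl carbon. Within the data shown here, no measured step shares this change: the step from compound 1 to compound 2 exchanges one open chain for another and leaves the carbonyl carbon's neighbour intact, so it tells nothing about closing a four-membered ring at that position. The estimate for compound 3 therefore rests on little and is set loosely between the two known values, the expected step being a 1.9-fold lower number from compound 2 to compound 3 (0.27 log units; within the scatter). For compound 3 a value of 3000 nM is expected, within a range of 600 nM to 15000 nM.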

Compound 3, half-maximal inhibitory concentration: 600 nM
Estimate against measurement, compound 3: 5.0-fold (0.70 log units) above; the range from low to high includes it.
By their numbers in this assay, from the lowest: compounds 3 and 1 (each within the scatter of the next); then compound 2.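

In this assay, azetidin-2-yl in place of 1-amino-2-methylbutyl on the carbonyl carbon gives a 9.3-fold lower number from compound 2 to compound 3 (0.97 log units; beyond the scatter), so this position accepts a four-membered ring carrying the nitrogen, a kind of group the two open chains could not speak to. Against 1-amino-3-carbamoylpropyl the same ring gives a 1.3-fold lower number from compound 1 to compound 3 (0.12 log units; within the scatter), so compound 3 and compound 1 read alike, and among these three compounds only compound 2 stands apart. Nothing at hand accounts for this difference.

As far as these compounds go, whether pyrrolidin-2-yl or piperidin-2-yl on the same carbonyl carbon would read like azetidin-2-yl remains open, as does the opposite configuration of the azetidin-2-yl stereocentre. Also open, from the compounds shown here alone, is how a carboxylic acid in place of the carbamoyl end of the chain in compound 1 would read.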